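Chain-shifted cyanoguanidine on the methylated core

A few compounds are considered here, and "the series" means these few. Any claim that something is new, unique, unknown or untested is made for them only; others in the source may bear on it.

Within the data shown here, compound 3 `CC/N=C(/NC#N)NCCCCn1nc(-c2ccccc2)cc(C)c1=O` stands lowest of the three compounds measured so far in a functional assay on the whole organism with Rattus norvegicus as the target, at a dose of 100 mg/kg (a higher number here means more inhibition at the dose given (going by the name of the read-out), a lower number less inhibition), giving 42.5%. The nearest is compound 2 `C/N=C(/NC#N)NCCCCCn1nc(-c2ccccc2)ccc1=O`, which in this assay gives 47.6%, a gap within the scatter; the furthest is compound 1 `CC/N=C(/NC#N)NCCCCn1nc(-c2ccccc2)ccc1=O`, which in this assay gives 58.8%, a gap beyond the scatter, as the step of a number 16.3 percentage points lower from compound 1 to compound 3 (beyond the scatter) shows.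

Compound 4 `C/N=C(/NC#N)NCCCCCn1nc(-c2ccccc2)cc(C)c1=O` differs from compound 3 by a group of 8 heavy atoms (4 carbon, 4 nitrogen; no ring) in place of a group of 8 heavy atoms (4 carbon, 4 nitrogen; no ring), on a saturated chain carbon, four bonds along the chain from an aromatic nitrogen. The same change has been measured once before, on the core without the added methyl: the step of a number 11.2 percentage points lower from compound 1 to compound 2 (beyond the scatter) was modest but beyond the scatter. Among the measured compounds shown here, no other step bears on it. The expectation for the step of a number 11.5 percentage points lower from compound 3 to compound 4 (beyond the scatter) is therefore a similar lowering in this assay, though with a single precedent the size is uncertain and a result within the scatter of compound 3 cannot be excluded.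

For compound 4 the estimate in this assay is 31%, with a range from 18% to 44%.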

Compound 4, a percentage reported as inhibition, in the whole organism at one dose (the size of the read-out at that dose, not a potency): 33.8%
Compound 4: the middle estimate sits 2.8 percentage points below what was measured; low and high end bracket the measured number.
By their numbers in this assay, from the lowest: compounds 4, 3 and 2 (each within the scatter of the next, the first and the last beyond it); then compound 1.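

On the core carrying the added methyl, the chain change gives a number 8.7 percentage points lower from compound 3 to compound 4 (within the scatter) in this assay, so this step alone is not distinguishable from the scatter, yet it agrees with the step on the core without the methyl: the same change on two cores in this assay, a number 11.2 percentage points lower (beyond the scatter) from compound 1 to compound 2 and a number 8.7 percentage points lower (within the scatter) from compound 3 to compound 4, 2.5 percentage points apart, within the scatter of two such steps

The methyl in place of hydrogen on an aromatic carbon can now be read on the second side chain too, where it gives a number 13.8 percentage points lower from compound 2 to compound 4 (beyond the scatter), and it matches its first reading: the same change on two cores in this assay, a number 16.3 percentage points lower (beyond the scatter) from compound 1 to compound 3 and a number 13.8 percentage points lower (beyond the scatter) from compound 2 to compound 4, 2.5 percentage points apart, within the scatter of two such steps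

Across these four compounds the two changes therefore combine roughly additively, and no compound goes against this.

The chain step alters the end alkyl group and the chain length together, so the compounds shown do not separate the two. Going by these compounds, whether a hexyl chain, or an ethyl group in place of the added methyl, would follow the same trend remains open.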